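Changing the group on sulfur in compound 1

A few compounds are considered here, and "the series" means these few. Any claim that something is new, unique, unknown or untested is made for them only; others in the source may bear on it.

In a functional assay on DU-145 cells (Homo sapiens) for inhibition, read by trypan blue exclusion, with a stated time of 96 h (on this read-out lower numbers stand for stronger inhibition of growth and higher numbers for weaker inhibition of growth), compound 1 (`COc1cc(OC)c(/C=C(/Sc2ccc(C)cc2)C(=O)c2ccc(Cl)cc2)c(OC)c1`) records > 100000 nM as its result, which is a limit and not a number. Two related compounds do give numbers: compound 2 (`COc1ccc(/C=C(\C(=O)c2ccc(Cl)cc2)S(=O)(=O)c2ccc(C)cc2)cc1O`) stands at 1000 nM on this test, and compound 3 (`Cc1cc(C)cc(/C=C(/Sc2ccc(Br)cc2)C(=O)c2ccc(Cl)cc2)c1`) stands at 10000 nM on it. Compound 4 (`COc1cc(OC)c(/C=C(/SCc2ccc(F)cc2)C(=O)c2ccc(Cl)cc2)c(OC)c1`) keeps the core of compound 1 and carries 4-fluorobenzyl in place of 4-methylphenyl on a sulfur. Going by the values given here, no measured step isolates this change, so any forecast is loose. The expected step of an at least 10-fold lower number from compound 1 to compound 4 (1.00 log units; beyond the scatter) runs towards stronger inhibition of growth in this assay and is only an estimate. This expectation leans on compound 3 at 10000 nM as a guide. Compound 4 is expected at 10000 nM in this assay, with an estimated range from 1000 nM to 100000 nM for it.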

Compound 4, concentration for 50% growth inhibition: 10000 nM
Compound 4: the middle estimate sits on the measured number at the digits printed, within the range that was stated.
By their numbers in this assay, from the lowest: compound 2; then compounds 3 and 4 (each within the scatter of the next). At a limit, above all of these: compound 1.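

With 4-fluorobenzyl in place of 4-methylphenyl on a sulfur, the core of compound 1 gives a measurable result in this assay, a change of an at least 10-fold lower number from compound 1 to compound 4 (1.00 log units; beyond the scatter). The group on this sulfur alone therefore separates a compound at a limit from one with a number. Compound 1 has only a limit, which leaves the full size of the step unknown: the limit of > 100000 nM in this assay, at which 1 of the 4 values shown sits.

The step changes the benzyl link and the fluorine together, and the compounds shown do not separate the two. They also leave open how an unsubstituted benzyl or a longer chain ending in an amine would behave on this sulfur.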